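Bromo for chloro repeated on a second core

The source may report more compounds than this note shows. Statements on the series, on what has been measured and on what is new or still open speak of the compounds shown alone.

Compound 1 `Cn1c(=O)c2[nH]c(SCC(=O)c3ccc(Cl)cc3)nc2n(C)c1=O` and compound 2 `Cn1c(=O)c2[nH]c(SCC(=O)c3ccc(Br)cc3)nc2n(C)c1=O` share one core and differ in a single halogen; compound 3 `Cn1c(=O)[nH]c2nc(SC/C(=N/O)c3ccc(Cl)cc3)[nH]c2c1=O` and the not yet measured compound 4 `Cn1c(=O)[nH]c2nc(SC/C(=N/O)c3ccc(Br)cc3)[nH]c2c1=O` share another core, and the difference between the two cores is not broken down here.

In a functional assay on HT-29 cells (Homo sapiens) for inhibition, read by MTT assay, with a stated time of 48 h (on this read-out higher numbers stand for weaker inhibition and lower numbers for stronger inhibition), compound 1 gives 9900 nM. Compound 2 gives 6500 nM. The change between them, (bromo in place of chloro on an aromatic carbon), made a step of a 1.5-fold lower number from compound 1 to compound 2 (0.18 log units; within the scatter). Compound 3 gives 1800 nM, the lowest number among the three measured compounds, with its steps to compound 2 and compound 1 both beyond the scatter.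

Compound 4 carries the same change on the core of compound 3, namely (bromo in place of chloro on an aromatic carbon), with the place described in the same words as before, so this is the same change, occurring twice in all among the compounds shown. Going by the values given here, the step from compound 3 to compound 4 in this assay is expected to be small, a 1.2-fold lower number from compound 3 to compound 4 (0.08 log units; within the scatter), because the single precedent a 1.5-fold lower number from compound 1 to compound 2 (0.18 log units; within the scatter) stayed within the scatter. Compound 4 is therefore estimated at 1500 nM, with the expected range running from 700 nM to 3500 nM.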

Compound 4, half-maximal inhibitory concentration: 2000 nM
Beside the measured number, compound 4's estimate is 1.3-fold (0.12 log units) below it; the measured number falls inside the stated range.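

In this assay the change gives a 1.1-fold higher number from compound 3 to compound 4 (0.05 log units; within the scatter), and its outcome on the core of compound 3 cannot be told apart from its outcome on the core of compound 1: the same change on two cores in this assay, a 1.5-fold lower number (0.18 log units; within the scatter) from compound 1 to compound 2 and a 1.1-fold higher number (0.05 log units; within the scatter) from compound 3 to compound 4, 1.7-fold (0.23 log units) apart, within the scatter of two such steps

On these two pairs, then, 4-chlorophenyl and 4-bromophenyl are interchangeable on this read-out, and the absence of a measurable step carries from one core to the other. This rests on two pairs in a single cell assay, so it does not show that the same would hold on a further core or in other cells, and it says nothing about the gap between the two cores, which differ in more than one place.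

The compounds shown carry only chloro and bromo at this place on the aromatic ring, so it remains open whether fluoro, methoxy, an amine or a carboxylic acid there would leave the number equally unmoved. Also open, going by these compounds, is whether any such group would behave alike on both cores.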